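Trifluoromethyl for methyl on the fused ring: toxicity notes

A few compounds are considered here, and "the series" means these few. Any claim that something is new, unique, unknown or untested is made for them only; others in the source may bear on it.

Three compounds carry numbers in an ADME assay on C6 cells (Rattus norvegicus) for cytotoxicity; on this read-out lower numbers stand for higher toxicity in this test and higher numbers for lower toxicity in this test. Compound 1 `Cc1cc2ccccc2n1CCNC(=O)/C=C/c1ccc(OCCO)c(OCCO)c1` gives 92300 nM, compound 3 `Cc1cc2ccccc2n1CCNC(=O)/C=C/c1ccc(OCCO)cc1` gives 81700 nM, and compound 2 `COc1cc(/C=C/C(=O)NCCn2c(C)cc3ccccc32)cc(OC)c1OCCO` gives 43300 nM. Compound 2 shows the lowest number of the three, though its gap to compound 3 lies within the scatter; only compound 1 stands beyond it. Among the measured compounds shown here, the single measured step, a 1.1-fold lower number from compound 1 to compound 3 (0.05 log units; within the scatter), concerns a different position and stays within the scatter. Compound 4 `COc1cc(/C=C/C(=O)NCCn2c(C(F)(F)F)cc3ccccc32)cc(OC)c1OCCO` differs from compound 2 by trifluoromethyl in place of methyl on an aromatic carbon. For the measured compounds named here, no measured step touches this change, so the series offers no ground for a shift beyond the scatter in this assay. The expected step is a 1.1-fold lower number from compound 2 to compound 4 (0.03 log units; within the scatter). Compound 4 is estimated at 40000 nM, with a range from 20000 nM to 80000 nM.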

Compound 4, half-maximal cytotoxic concentration: 31200 nM
Compound 4: the middle estimate sits 1.3-fold (0.11 log units) above what was measured; low and high end bracket the measured number.
By their numbers in this assay, from the lowest: compounds 4, 2, 3 and 1 (each within the scatter of the next, the first and the last beyond it).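

In this assay the step at this position reads a 1.4-fold lower number from compound 2 to compound 4 (0.14 log units; within the scatter) and stays within the scatter. On the aromatic carbon next to the ring nitrogen, trifluoromethyl with 4 heavy atoms thus takes the place of methyl with 1 without a shift beyond the scatter, a reading that holds for this one pair only. No measured finding offers an explanation for this result.

From the compounds shown here alone, whether the same change behaves alike on the cores of compound 1 and compound 3 remains open. Also open, going by these compounds, is how an amine, a carboxylic acid or a longer alkyl chain would read at this position.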